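Cyano for Methyl on the Benzylic Ring of a Hydroxamate

The source may report more compounds than this note shows. Statements on the series, on what has been measured and on what is new or still open speak of the compounds shown alone.

The series rests on a shared core carrying a hydroxamic acid chain, and two members of it have been measured so far. Compound 1 `Cc1cccc(CN2CC=C(CCC(=O)NO)C2=O)c1` is one of them; in a functional assay on PC-3 cells (Homo sapiens) for inhibition, read by sulforhodamine B assay (on this read-out higher numbers stand for weaker inhibition of growth and lower numbers for stronger inhibition of growth), compound 1 gives 4620 nM. Compound 2 `O=C(CCC1=CCN(CCCc2ccc(Cl)cc2)C1=O)NO` differs from it in the group on the ring nitrogen, and in this assay compound 2 gives 3480 nM. Compound 1 carries the higher of the two numbers, but the gap between compound 1 and compound 2 lies within the usual scatter, so the two values show no difference in growth inhibition that can be trusted.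

The next compound to be examined is compound 3 `N#Cc1cccc(CN2CC=C(CCC(=O)NO)C2=O)c1`. It differs from compound 1 in one place: cyano in place of methyl on an aromatic carbon. Going by the values given here, no measured pair in this set shows the effect of such a change, so there is nothing to set the size of the step against.

Given that, the step of a 1.2-fold lower number from compound 1 to compound 3 (0.06 log units; within the scatter) is expected to be small, with no direction beyond the scatter. The estimate for compound 3 in this assay is 4000 nM, with a likely range from 1500 nM to 11000 nM.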

Compound 3, concentration for 50% growth inhibition: 7920 nM
For compound 3 the middle estimate is 2.0-fold (0.30 log units) below the measured one; the measured number falls inside the stated range.
By their numbers in this assay, from the lowest: compounds 2, 1 and 3 (each within the scatter of the next, the first and the last beyond it).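

Going by these compounds alone, compound 1 and compound 3 form the first pair in this set that isolates a single change, and in this assay cyano in place of methyl on an aromatic carbon, meta to a large group, gives a 1.7-fold higher number from compound 1 to compound 3 (0.23 log units; within the scatter). This position on the six-membered aromatic ring of carbon only therefore accepts the exchange of methyl for cyano, which brings in one more heavy atom and a hydrogen-bond acceptor, with no difference in growth inhibition that can be trusted, though that reading rests on this one pair. Nothing at hand explains why the two groups give values within the scatter of each other.

Going by these compounds, whether this position is as undemanding for other groups stays open, since an amine, a carboxylic acid or a longer chain on the same aromatic carbon might give a clearly different number from the methyl of compound 1. On these data alone, it is also open whether the same exchange of methyl for cyano would give a similarly small step with another group on the ring nitrogen of the shared core, such as the chlorophenyl-bearing chain of compound 2.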